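A few compounds are considered here, and "the series" means these few. Any claim that something is new, unique, unknown or untested is made for them only; others in the source may bear on it.

Of the compounds shown here, three have been measured in a functional assay on OVCAR-5 cells (Homo sapiens) for cytotoxicity, read by sulforhodamine B assay, with a stated time of 48 h; a lower number here means a stronger inhibitor of growth, a higher number a weaker inhibitor of growth. Compound 1 `ClCc1ccccc1Cn1cnc2c(Cl)nc(Cl)nc21` gives 1580 nM. Compound 2 `ClCc1ccccc1Cn1cnc2c(Cl)ncnc21`, which carries one chloro group fewer, gives 2450 nM. Compound 3 `ClCc1ccccc1Cn1cnc2ncnc(Cl)c21` has the same atoms as compound 2 joined differently; the difference between the two cores is not broken down here. In this assay compound 3 gives 2810 nM, a number within the scatter of compound 2 and also of compound 1, so no order among the three can be claimed.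

Among the compounds with values here, the one counted change among the measured compounds is chloro in place of hydrogen on an aromatic carbon. It made the step of a 1.6-fold lower number from compound 2 to compound 1 (0.19 log units; within the scatter).

Compound 4 `ClCc1ccccc1Cn1cnc2nc(Cl)nc(Cl)c21` has not yet been measured. Within the data shown here, it differs from compound 3 by chloro in place of hydrogen on an aromatic carbon, which is the same change as the one from compound 2 to compound 1, at a place described in the same words. The expectation for compound 4 therefore rests on the measured step of a 1.6-fold lower number from compound 2 to compound 1 (0.19 log units; within the scatter), taken from the value of compound 3. In this assay compound 4 is expected to give 1900 nM, with the likely range from 1000 nM to 3600 nM. The expected step of a 1.5-fold lower number from compound 3 to compound 4 (0.17 log units; within the scatter) is a small one, matching the earlier one in size.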

Compound 4, concentration for 50% growth inhibition: 2690 nM
Compound 4: the middle estimate sits 1.4-fold (0.15 log units) below what was measured; the measured number falls inside the stated range.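

In this assay, chloro in place of hydrogen on an aromatic carbon gives a 1.0-fold lower number from compound 3 to compound 4 (0.02 log units; within the scatter), so compound 4 cannot be told apart from compound 3. Set beside the earlier step, the change reads alike on the two cores: the same change on two cores in this assay, a 1.6-fold lower number (0.19 log units; within the scatter) from compound 2 to compound 1 and a 1.0-fold lower number (0.02 log units; within the scatter) from compound 3 to compound 4, 1.5-fold (0.17 log units) apart, within the scatter of two such steps. This shows that neither core gives a step beyond the scatter and that nothing here separates the two cores in their response to this change, but it does not show that the change has any real effect on growth inhibition, nor that a real effect carries from one core to the other, and it says nothing about any further core.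

As far as these compounds go, all four compounds keep at least one chloro group on the shared core, so what an amine or a methoxy group would give in its place stays open. From the compounds shown here alone, they also all carry the chloromethyl group, and what a hydroxymethyl or a plain methyl group would give there is equally open.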